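Hydroxy on the Phenyl Ring in Two Pyrrole Series

The source may hold more compounds than are shown below. What is called first, only, known or untested is meant among the compounds shown, and "the series" means these compounds.

Of the compounds shown here, three have been tested in a functional assay on MCF7 cells (Homo sapiens) for cytotoxicity, read by MTT assay, with stated times of 6 h and 48 h; a lower number here means a stronger inhibitor, a higher number a weaker inhibitor. Compound 2, `O=C(/C=C/c1cc(Br)c(Br)[nH]1)c1ccccc1`, gives 12200 nM in this assay. Compound 1, `O=C(/C=C/c1cc(Br)c(Br)[nH]1)c1ccccc1O`, carries one extra group, and in this assay compound 1 gives 1490 nM. The change between them is hydroxy in place of hydrogen on an aromatic carbon, and it made an 8.2-fold lower number from compound 2 to compound 1 (0.91 log units; beyond the scatter). Compound 3, `Cn1c(-c2cc(-c3ccccc3)no2)cc(Br)c1Br`, is built on a different core; how that core differs from the core of compound 2 is not broken down here. In this assay compound 3 reaches only a limit of the assay, >= 100000 nM, and no number is known for it.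

Compound 4, `Cn1c(-c2cc(-c3ccccc3O)no2)cc(Br)c1Br`, has not yet been measured in this assay. It stands to compound 3 exactly as compound 1 stands to compound 2: the change is hydroxy in place of hydrogen on an aromatic carbon, the same change as the one already seen. Since the step from compound 2 to compound 1 was measured and the starting point here sits at the limit of >= 100000 nM in this assay, at which 1 of the 3 values shown sits, the expectation for compound 4 rests on carrying that earlier step over onto an unknown starting number. Compound 4 is therefore expected to show a step of about an at least 2.5-fold lower number from compound 3 to compound 4 (0.39 log units; beyond the scatter) in this assay, with wide uncertainty. The estimate for compound 4 in this assay is 40000 nM, somewhere between 8000 nM and 200000 nM.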

Compound 4, half-maximal inhibitory concentration: >= 100000 nM
Compound 4: no number, only a limit; the forecaster's own chance of this, stated with the estimate: 45%; middle value at least 2.5-fold (0.39 log units) from the limit.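

In this assay compound 4 gives only a limit, >= 100000 nM, and compound 3 also stands at a limit, so the step between these two compounds cannot be read: the limit of >= 100000 nM in this assay, at which 2 of the 4 values shown sit.

The compounds shown leave open whether hydroxy in place of hydrogen does anything on the core of compound 3, as neither compound 3 nor compound 4 has an actual number to compare.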